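A few compounds are considered here, and "the series" means these few. Any claim that something is new, unique, unknown or untested is made for them only; others in the source may bear on it.

Of the compounds shown here, three that share one core have been measured in a functional assay on HepG2 cells (Homo sapiens) for cytotoxicity, read by MTT assay, with a stated time of 72 h; a lower number here means a stronger inhibitor, a higher number a weaker inhibitor. Compound 1 `O=C(Nc1ccc(Oc2ccnc3[nH]ccc23)cc1)c1nn(-c2ccc(Cl)cc2)ccc1=O` gives 19500 nM. Compound 2 `O=C(Nc1ccc(Oc2ccnc3[nH]ccc23)cc1)c1nn(-c2ccc(Br)cc2F)ccc1=O` gives 46400 nM. Compound 3 `O=C(Nc1ccc(Oc2ccnc3[nH]ccc23)cc1)c1nn(-c2ccc(Cl)c(F)c2)ccc1=O` gives 5240 nM, the lowest of the three numbers. The measured steps are a 2.4-fold higher number from compound 1 to compound 2 (0.38 log units; beyond the scatter), a 3.7-fold lower number from compound 1 to compound 3 (0.57 log units; beyond the scatter) and an 8.9-fold lower number from compound 2 to compound 3 (0.95 log units; beyond the scatter). Compound 4 `O=C(Nc1ccc(Oc2ccnc3[nH]ccc23)cc1)c1nn(-c2ccc(Cl)c(C(F)(F)F)c2)ccc1=O` differs from compound 3 by trifluoromethyl in place of fluoro on an aromatic carbon, the change sitting on an aromatic carbon of a six-membered aromatic ring of carbon only, ortho to a chloro group. Among the measured compounds shown here, no measured step exchanges a fluoro for a trifluoromethyl. The step of a 3.7-fold lower number from compound 1 to compound 3 (0.57 log units; beyond the scatter) shows that a substituent at this ring position moved the number beyond the scatter, and the step of an 8.9-fold lower number from compound 2 to compound 3 (0.95 log units; beyond the scatter) shows that a rearrangement of the halogens did so as well, yet neither tells the direction for a trifluoromethyl. In this assay the expected step is therefore a 1.2-fold lower number from compound 3 to compound 4 (0.07 log units; within the scatter), which is not expected to go beyond the scatter. The estimate for compound 4 is 4500 nM, with a range from 1500 nM to 14000 nM.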

Compound 4, half-maximal inhibitory concentration: 1320 nM
For compound 4 the middle estimate is 3.4-fold (0.53 log units) above the measured one, outside the stated range (below it).
By their numbers in this assay, from the lowest: compound 4; then compound 3; then compound 1; then compound 2.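

In this assay, trifluoromethyl in place of fluoro, ortho to a chloro group, gives a 4.0-fold lower number from compound 3 to compound 4 (0.60 log units; beyond the scatter) and so extends the fall already seen on going from hydrogen to fluoro at this position, while the full change from hydrogen to trifluoromethyl amounts to a 15-fold lower number from compound 1 to compound 4 (1.17 log units; beyond the scatter) in this series. The widest step among the four compounds, a 35-fold lower number from compound 2 to compound 4 (1.55 log units; beyond the scatter), comes with the exchange of the whole aryl group on the aromatic nitrogen. Nothing available here bears on why the number falls with this change.

From the compounds shown here alone, whether a nitrile, a methoxy group or an amine at this position would continue or reverse the fall remains open. Also open, going by these compounds, is whether trifluoromethyl would have the same effect on a ring without the chloro group.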